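Shortening the alkoxy chain toward a methoxy analogue

A few compounds are considered here, and "the series" means these few. Any claim that something is new, unique, unknown or untested is made for them only; others in the source may bear on it.

Of the compounds shown here, three have been tested in a functional assay on the whole organism (strain albino CF-1) with Mus musculus as the target, in the maximal electroshock model, with a stated time of 4 h; a lower number here means that less compound is needed, a higher number that more compound is needed for the effect. Compound 1 `C=CCOc1cccc(/C=N/n2c(-c3ccccc3)nc3ccccc3c2=O)c1` gives 300 mg/kg, compound 2 `O=c1c2ccccc2nc(-c2ccccc2)n1/N=C/c1cccc(OCc2ccccc2)c1` gives 300 mg/kg, and compound 3 `CCOc1cccc(/C=N/n2c(-c3ccccc3)nc3ccccc3c2=O)c1` gives 100 mg/kg. Compound 3 therefore stands at the lowest number of the three: the steps of a 3.0-fold lower number from compound 1 to compound 3 (0.48 log units; beyond the scatter) and a 3.0-fold lower number from compound 2 to compound 3 (0.48 log units; beyond the scatter) both run in its favour, while no change at the digits printed from compound 1 to compound 2 (within the scatter) shows no separation between the two larger groups.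

Compound 4 `COc1cccc(/C=N/n2c(-c3ccccc3)nc3ccccc3c2=O)c1` differs from compound 3 by hydrogen in place of methyl on a saturated chain carbon bound to an oxygen on an aromatic ring. The two steps that bear on this position, from compound 1 and from compound 2 to compound 3, each shrink the group on the saturated chain carbon and each lower the number by the same modest amount. For the measured compounds named here, no measured step replaces a group with hydrogen at this place. The step from methyl to hydrogen is not directly covered. On the trend seen so far, compound 4 is expected to give a number near or somewhat below that of compound 3, the expected step being no change at the digits printed from compound 3 to compound 4 (within the scatter), which may also fall within the scatter. Compound 4 is estimated at 100 mg/kg, in the range 30 mg/kg to 300 mg/kg.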

Compound 4, minimum effective dose: 100 mg/kg
Estimate against measurement, compound 4: no gap at the digits printed; the measured number falls inside the stated range.
By their numbers in this assay, from the lowest: compounds 3 and 4 (each within the scatter of the next); then compounds 1 and 2 (each within the scatter of the next).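

Within this assay the exchange of methyl for hydrogen on the saturated chain carbon bound to an oxygen on an aromatic ring, which turns 3-ethoxyphenyl into 3-methoxyphenyl, gives no change at the digits printed from compound 3 to compound 4 (within the scatter) and so separates nothing at this place. Hydrogen there stands apart from the larger groups just as methyl does, with a 3.0-fold lower number from compound 2 to compound 4 (0.48 log units; beyond the scatter) and a 3.0-fold lower number from compound 1 to compound 4 (0.48 log units; beyond the scatter) matching in size the steps from those two compounds to compound 3, so the four compounds form two pairs, with methyl and hydrogen on one side and vinyl and phenyl on the other. No measurement shown here accounts for this division.

On these data alone, it remains open whether a saturated chain longer than ethyl, such as propyl or butyl, would sit with the first pair or the second. The effect of an amine or a carboxylic acid at the end of the chain is also unknown.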